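The source may hold more compounds than are shown below. What is called first, only, known or untested is meant among the compounds shown, and "the series" means these compounds.

Measured compounds in a functional assay on L1210 cells (Mus musculus), read by cell counting, with a stated time of 48 h; on this read-out higher numbers stand for weaker inhibition and lower numbers for stronger inhibition:
- compound 1 `COc1ccc(/C=C/c2ccc(C)cc2)cc1` — in this assay compound 1 gives only a limit, > 200 ug/mL, not a number.
- compound 2 `Fc1ccc(/N=C/c2cccs2)cc1Cl` — in this assay compound 2 gives 3.2 ug/mL.
- compound 3 `Cc1ccc(/C=C/c2ccccc2F)cc1` — in this assay compound 3 gives 72 ug/mL.

Compound 3 stands at the highest of the two numbers given; the nearest number is that of compound 2, which sits at a markedly lower figure, a gap beyond the usual scatter. The third entry, that of compound 1, is a limit of the assay (the limit of > 200 ug/mL in this assay, at which 1 of the 3 values shown sits), so it cannot be placed against the two numbers.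

The next compound, compound 4 `Fc1ccc(/C=C/c2ccccc2F)cc1`, is not yet measured in this assay. It differs from compound 3 in one place: fluoro in place of methyl on an aromatic carbon. Among the measured compounds shown here, no measured pair in the set shows this same change, so no step size can be read off for it. Given the small size of the swap, the expected step from compound 3 to compound 4, a 1.1-fold higher number from compound 3 to compound 4 (0.05 log units; within the scatter), is not expected to go beyond the scatter in either direction. Compound 4 is therefore estimated at 80 ug/mL, within a range from 30 ug/mL to 200 ug/mL.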

Compound 4, half-maximal inhibitory concentration: 62 ug/mL
Beside the measured number, compound 4's estimate is 1.3-fold (0.11 log units) above it; measured number inside the range.
By their numbers in this assay, from the lowest: compound 2; then compounds 4 and 3 (each within the scatter of the next). At a limit, above all of these: compound 1.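

Fluoro in place of methyl on an aromatic carbon, para to a group of 9 heavy atoms, provides the first step in the series that can be read in this assay, namely a 1.2-fold lower number from compound 3 to compound 4 (0.06 log units; within the scatter). Among the compounds shown here, until this pair, no two measured compounds differed in one place, so nothing could be read about this position or this change; the position now has one measured exchange, and that exchange stays within the scatter, with one heavy atom replacing another and no ring, hydrogen-bond donor, hydrogen-bond acceptor or net charge entering or leaving. No measured property at hand bears on this result.

Open, from the compounds shown here alone, is whether the position stays this insensitive with groups of another kind: an amine, a carboxylic acid or a longer chain in place of the methyl would test that on the shared core of compound 3 and compound 4. Also open, going by these compounds, is whether the same exchange of fluoro for methyl gives a comparable step on a different core or at another place on this one.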